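This account rests on a few compounds, and the source may have more. Where it says the series, first, only, none or still open, it means among the compounds named here.

Measured in a toxicity assay on CCRF-CEM cells (Homo sapiens) for cytotoxicity; a lower number here means that less compound is tolerated, a higher number that more compound is tolerated:
compound 1 `CNc1cccc2c1nc(-c1c(F)cccc1F)n2Cc1c(F)cccc1F` gives 27.2 uM.
compound 2 `CN(C)c1cccc2c1nc(-c1c(F)cccc1F)n2Cc1c(F)cccc1F` gives > 100 uM; this is a limit of the assay, not a number.
compound 3 `N=C(NO)c1cccc2c1nc(-c1c(F)cccc1F)n2Cc1c(F)cccc1F` gives 23.1 uM.

Compound 3 stands lowest of the two numbers shown in this assay, and the nearest is compound 1: a 1.2-fold lower number from compound 1 to compound 3 (0.07 log units; within the scatter), within the scatter. Compound 2 sits at the limit of > 100 uM in this assay, at which 1 of the 3 values shown sits. From there the step is an at least 4.3-fold lower number from compound 2 to compound 3 (0.63 log units; beyond the scatter), and the step of an at least 3.6-fold higher number from compound 1 to compound 2 (0.56 log units; beyond the scatter) is likewise beyond the scatter.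

Compound 4 `NCc1cccc2c1nc(-c1c(F)cccc1F)n2Cc1c(F)cccc1F` differs from compound 3 by a group of 2 heavy atoms (1 carbon, 1 nitrogen; no ring) in place of a group of 4 heavy atoms (1 carbon, 2 nitrogen, 1 oxygen; no ring), on an aromatic carbon. Within the data shown here, no measured step brings in aminomethyl. Among the measured compounds shown here, the two steps at this position differ in size: the one from compound 1 is within the scatter, the one from compound 2 is beyond it. Compound 1 carries a group of 2 heavy atoms at the same place and its value, 27.2 uM, lies within the scatter of compound 3, so for this assay the expected step is a 1.1-fold higher number from compound 3 to compound 4 (0.03 log units; within the scatter), no change beyond the scatter. The estimate for compound 4 is 25 uM, within 9 uM to 70 uM.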

Compound 4, half-maximal toxic concentration: 49.3 uM
Compound 4: middle estimate off by 2.0-fold (0.29 log units), on the low side; measured number inside the range.
By their numbers in this assay, from the lowest: compounds 3, 1 and 4 (each within the scatter of the next, the first and the last beyond it). At a limit, above all of these: compound 2.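

In this assay, aminomethyl on this aromatic carbon cannot be told apart from methylamino, the step being a 1.8-fold higher number from compound 1 to compound 4 (0.26 log units; within the scatter). Against the group that leaves compound 3, the same aminomethyl does register, with a 2.1-fold higher number from compound 3 to compound 4 (0.33 log units; beyond the scatter), so the three values form a chain in which only the two ends separate, not distinct tiers. Compound 2 remains a limit and not a number, so an at least 2.0-fold lower number from compound 2 to compound 4 (0.30 log units; that floor lies within the scatter) gives only a floor, and whether aminomethyl truly stands apart from dimethylamino cannot be read: the limit of > 100 uM in this assay, at which 1 of the 4 values shown sits.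

Still open, from the compounds shown here alone, is whether dimethylaminomethyl at this place would read like compound 2 or like compound 4. Also open, going by these compounds, is how a carboxylic acid, a nitrile or a longer amine chain such as aminoethyl would read in this assay.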